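The source may report more compounds than this note shows. Statements on the series, on what has been measured and on what is new or still open speak of the compounds shown alone.

Measured so far:
- compound 1 `COc1cc(-c2cc(/C=C/C(=O)c3ccc(Cl)c(Cl)c3)[nH]n2)cc(OC)c1OC`: 96%
- compound 2 `COc1ccc(C(=O)/C=C/c2cc(-c3cc(OC)c(OC)c(OC)c3)n[nH]2)cc1OC`: 93%

In a functional assay on HCC 2998 cells (Homo sapiens) for cytotoxicity, read by sulforhodamine B assay, with a stated time of 48 h, tested at 0.01 uM (on this read-out higher numbers stand for a weaker effect at the one concentration tested and lower numbers for a stronger effect), compound 1 gives 96% and compound 2 gives 93%. Compound 2 has the lower of the two numbers, but only by a number 3 percentage points lower from compound 1 to compound 2 (within the scatter), which lies within the scatter, so the two compounds cannot be told apart on this read-out; both show little effect at the single concentration tested.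

Compound 3 `COc1ccc(C(=O)/C=C/c2cc(-c3cc(OC)c(OC)c(OC)c3)n[nH]2)cc1` is the next step: hydrogen in place of methoxy on an aromatic carbon. Within the data shown here, the one step measured so far, from compound 1 to compound 2, also changed the groups on the ring attached to the carbonyl carbon, and it moved the number by no more than the scatter. By that guide the removal of one methoxy group is expected to leave the number much where compound 2 stands, with a step of a number 1 percentage points higher from compound 2 to compound 3 (within the scatter) that is not expected to exceed the scatter. Compound 3 is therefore estimated at 94%, within a range of 85% to 100%.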

Compound 3, a percentage reported as activity, at one concentration (the size of the read-out at that concentration, not a potency): 101%
Beside the measured number, compound 3's estimate is 7 percentage points below it; measured number above the stated range.
By their numbers in this assay, from the lowest: compounds 2, 1 and 3 (each within the scatter of the next).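

Among these compounds, this is the first change made within the ring on the carbonyl carbon, rather than a swap of one substitution pattern for another. In this assay, cutting 3,4-dimethoxyphenyl back to 4-methoxyphenyl gives a step (a number 8 percentage points higher from compound 2 to compound 3 (within the scatter)) that shows this methoxy group, ortho to a methoxy group, can be removed with no difference that stands out from the scatter, and the comparison with the dichloro ring (a number 5 percentage points higher from compound 1 to compound 3 (within the scatter)) likewise separates nothing. Nothing available offers an explanation for this result.

Still open, as far as these compounds go, is whether this ring matters at all, since all three compounds show little effect at the single concentration tested. An amine or a carboxylic acid on this ring, or a longer chain in place of the methoxy, could show whether any group there shifts the number beyond the scatter.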